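Swapping the sulfonyl aryl group in a vinyl sulfone series

This account rests on a few compounds, and the source may have more. Where it says the series, first, only, none or still open, it means among the compounds named here.

Measured compounds:
compound 1 `COc1ccc(S(=O)(=O)/C(=C/c2ccc(Br)cc2)C(=O)c2ccc(Br)cc2)cc1` with 6000 nM
compound 2 `COc1ccc(S(=O)(=O)/C(=C/c2ccc(Cl)cc2Cl)C(=O)c2ccc(Br)cc2)cc1` with 20000 nM
compound 3 `Cc1ccc(CS(=O)(=O)/C(=C/c2ccccc2Br)C(=O)c2ccc(Cl)cc2)cc1` with 25000 nM

Of the compounds shown here, three sharing a vinyl sulfone core have been measured in a functional assay on DU-145 cells (Homo sapiens) for inhibition, read by trypan blue exclusion, with a stated time of 96 h; a lower number here means a stronger inhibitor of growth, a higher number a weaker inhibitor of growth. Compound 1 gives the lowest number of the three; the nearest is compound 2, and that pair shows a 3.3-fold higher number from compound 1 to compound 2 (0.52 log units; beyond the scatter). Compound 3 lies furthest from compound 1, but it differs from compound 1 in more than one place, so its number is only a loose point of reference.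

Compound 4 `O=C(/C(=C\c1ccc(Br)cc1)S(=O)(=O)Cc1ccc(F)cc1)c1ccc(Br)cc1` has not yet been measured. It differs from compound 1 at the sulfonyl sulfur: 4-fluorobenzyl in place of 4-methoxyphenyl on a sulfonyl sulfur. Within the data shown here, no measured step touches this position, since the one counted step concerns the aryl group on the double-bonded chain carbon. Compound 3, which carries a benzyl group on its sulfonyl sulfur, gives a higher number than compound 1, yet its other changes confound that reading. In this assay the step from compound 1 to compound 4 is therefore expected to be small, leaning toward a higher number, as a 1.7-fold higher number from compound 1 to compound 4 (0.22 log units; within the scatter). Compound 4 is estimated at 10000 nM, with a range from 3000 nM to 35000 nM.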

Compound 4, concentration for 50% growth inhibition: 25000 nM
Beside the measured number, compound 4's estimate is 2.5-fold (0.40 log units) below it, within the range that was stated.
By their numbers in this assay, from the lowest: compound 1; then compounds 2, 3 and 4 (each within the scatter of the next).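

In this assay, the sulfonyl sulfur proves to be a position that responds to change: 4-fluorobenzyl in place of 4-methoxyphenyl gives a 4.2-fold higher number from compound 1 to compound 4 (0.62 log units; beyond the scatter), the first step read directly at this place. The two groups match in heavy atom count and in their single six-membered aromatic ring, so those counts do not separate them, although the hydrogen-bond acceptor count differs. No available evidence bears on why the number rises with this change.

The compounds shown do not separate the effect of the fluorine from that of the benzyl arrangement, and a 4-methoxybenzyl group on the sulfonyl sulfur would tell those two apart. On these data alone, how a 4-aminophenyl group at this place would read also remains open.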